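This account rests on a few compounds, and the source may have more. Where it says the series, first, only, none or still open, it means among the compounds named here.

Of the compounds shown here, three built on a shared core have been tested in a functional assay on MCF-A cells (Homo sapiens) for cytotoxicity; on this read-out higher numbers stand for weaker inhibition of growth and lower numbers for stronger inhibition of growth. Compound 1, `CSc1ccc(C2=C(c3ccc(F)c(F)c3)C(=O)N3CCCC3C2)cc1`, gives 800 nM in this assay. Compound 2, `CSc1ccc(C2=C(c3ccc(F)c(C)c3)C(=O)N3CCCC3C2)cc1`, gives 500 nM. Compound 3, `CSc1ccc(C2=C(c3ccc(C)cc3)C(=O)N3CCCC3C2)cc1`, gives 600 nM. Compound 2 and compound 3 differ in the group attached to the shared core: 4-methylphenyl in place of 4-fluoro-3-methylphenyl on a double-bonded ring carbon. That change produced a 1.2-fold higher number from compound 2 to compound 3 (0.08 log units; within the scatter). Between compound 1 and compound 3 the step was a 1.3-fold lower number from compound 1 to compound 3 (0.12 log units; within the scatter). None of these three numbers stands apart from the others.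

Compound 4, `CSc1ccc(C2=C(c3ccc(F)cc3)C(=O)N3CCCC3C2)cc1`, has not yet been measured. It differs from compound 3 in one place: fluoro in place of methyl on an aromatic carbon. A change of the same kind separates compound 2 from compound 1: fluoro in place of methyl on an aromatic carbon. That earlier change produced a 1.6-fold higher number from compound 2 to compound 1 (0.20 log units; within the scatter). The two places are not the same, however: in compound 1 the fluoro sits ortho to a fluoro group and meta to a large group, while in compound 4 it sits para to a large group, so this is the same kind of change rather than the same change. Going by the values given here, the earlier step is the only guide available, and it was small. Compound 4 is therefore expected to give about 800 nM in this assay, with a likely range from 400 nM to 1600 nM. The expected step is a 1.3-fold higher number from compound 3 to compound 4 (0.12 log units; within the scatter), which would sit within the usual scatter of such measurements.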

Compound 4, concentration for 50% growth inhibition: 800 nM
For compound 4 middle estimate and measured number coincide at the digits printed; the range from low to high includes it.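

In this assay, fluoro in place of methyl on an aromatic carbon gives a 1.3-fold higher number from compound 3 to compound 4 (0.12 log units; within the scatter), and this step agrees with the earlier step of the same kind on the other core: the same change on two cores in this assay, a 1.6-fold higher number (0.20 log units; within the scatter) from compound 2 to compound 1 and a 1.3-fold higher number (0.12 log units; within the scatter) from compound 3 to compound 4, 1.2-fold (0.08 log units) apart, within the scatter of two such steps. The two other new steps are also small: hydrogen in place of methyl gives a 1.6-fold higher number from compound 2 to compound 4 (0.20 log units; within the scatter), and hydrogen in place of fluoro gives no change at the digits printed from compound 1 to compound 4 (within the scatter). Within this series, the change from methyl to fluoro therefore carries from one core to the other without a detectable difference, but every step lies within the scatter, so the result shows neither that the change has a real effect on growth inhibition nor that such an effect would transfer reliably to further cores.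

The compounds shown leave open whether an amine, a carboxylic acid or a longer chain such as butyl, in place of the methyl or fluoro on this aromatic ring, would move the number beyond the scatter. They also leave open what replacing the methylthio group would do, as it stays the same in all four compounds, and whether the small steps seen here would hold in other cell types.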